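This account rests on a few compounds, and the source may have more. Where it says the series, first, only, none or still open, it means among the compounds named here.

Measured in a functional assay on KYSE-510 cells (Homo sapiens) for antiproliferative activity, read by crystal violet staining, with a stated time of 96 h; on this read-out higher numbers stand for weaker inhibition of growth and lower numbers for stronger inhibition of growth:

compound 1 `COc1cccc(S(=O)(=O)NC2=NCCN2C(=S)SN2CCn3c2nsc3=S)c1`: >= 20000 nM
compound 2 `O=S(=O)(NC1=NCCN1C(=S)SN1CCn2c1nsc2=S)c1cccc(OC(F)(F)F)c1`: >= 20000 nM
compound 3 `CC(=O)Nc1ccc(S(=O)(=O)NC2=NCCN2C(=S)SN2CCn3c2nsc3=S)cc1`: >= 20000 nM

Each of these three values is a limit of this assay, not a number. Compound 3 therefore stands only at a limit on the figures shown, and the two other values are limits as well; no measured step in the series can be read as a size. The step from compound 1 to compound 2, a trifluoromethyl in place of methyl on an oxygen on an aromatic ring, gives a step that the two limits leave unreadable from compound 1 to compound 2. The step from compound 1 to compound 3 gives a step that the two limits leave unreadable from compound 1 to compound 3. For the measured compounds named here, the only evidence on the measured steps is the limit of >= 20000 nM in this assay, at which 3 of the 3 values shown sit.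

Compound 4 `O=S(=O)(NC1=NCCN1C(=S)SN1CCn2c1nsc2=S)c1ccc(F)c(Cl)c1` differs from compound 3 by 3-chloro-4-fluorophenyl in place of 4-acetamidophenyl on a sulfonyl sulfur. Neither measured step bears directly on this change, and neither has a readable size. Going by the values given here, since every value so far sits at the limit, compound 4 is expected to stay near it, with an expected step of a number no higher from compound 3 to compound 4 (the limit leaves the size open). Compound 4 is estimated at 20000 nM, range 5000 nM to 60000 nM, in this assay.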

Compound 4, concentration for 50% growth inhibition: >= 20000 nM
Compound 4: no number, only a limit; the forecaster's own chance of this, stated with the estimate: 70%; the middle value lies on the limit itself.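

In this assay compound 4 gives >= 20000 nM, a limit and not a number. For the compounds shown here, no step from compound 1 or compound 3 to compound 4 can be read. The compounds shown leave open whether any change on the sulfonyl sulfur alters growth inhibition: the limit of >= 20000 nM in this assay, at which 4 of the 4 values shown sit.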